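Methoxy for Fluoro at the Para Position: Expected Cytotoxicity

This account rests on a few compounds, and the source may have more. Where it says the series, first, only, none or still open, it means among the compounds named here.

Measured so far:
compound 1, `COc1cc2nc(-c3ccc(-n4c(C)ccc4-c4ccc(C)cc4)cc3)sc2c(OC)c1OC`, 42500 nM
compound 2, `COc1cc2nc(-c3ccc(-n4c(C)ccc4-c4ccc(F)cc4)cc3)sc2c(OC)c1OC`, 43200 nM

Among the compounds with values here, in an ADME assay on MCF-10A cells (Homo sapiens) for cytotoxicity, read by MTT assay, with a stated time of 72 h (on this read-out higher numbers stand for weaker inhibition and lower numbers for stronger inhibition), compound 2 gives the highest of the two numbers, and its nearest neighbour is compound 1, whose value lies within the scatter of it: the step of a 1.0-fold higher number from compound 1 to compound 2 (0.01 log units; within the scatter) is the only measured step, and it showed no movement. Compound 3, `COc1ccc(-c2ccc(C)n2-c2ccc(-c3nc4cc(OC)c(OC)c(OC)c4s3)cc2)cc1`, is reached from compound 2 by methoxy in place of fluoro on an aromatic carbon. Within the data shown here, only that one step bears on the change, and it was flat, so no step beyond the scatter is expected in this assay in either direction. Compound 3 is therefore estimated at 43000 nM, within 22000 nM to 86000 nM, a step of a 1.0-fold lower number from compound 2 to compound 3 (0.00 log units; within the scatter).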

Compound 3, half-maximal inhibitory concentration: 43900 nM
The estimate for compound 3 lay 1.0-fold (0.01 log units) below the measured number, within the range that was stated.
By their numbers in this assay, from the lowest: compounds 1, 2 and 3 (each within the scatter of the next).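

In this assay the step of a 1.0-fold higher number from compound 2 to compound 3 (0.01 log units; within the scatter) for 4-fluorophenyl to 4-methoxyphenyl and the step of a 1.0-fold higher number from compound 1 to compound 3 (0.01 log units; within the scatter) for methoxy in place of methyl both stay within the scatter. Within the data shown here, this position, para to a large group, has now carried methyl, fluoro and methoxy with no separation among the three, whereas the earlier compounds offered only a single comparison. Nothing measured here accounts for this result. As far as these compounds go, whether an amine or a carboxylic acid at this position would move the number beyond the scatter remains open.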